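Thioether to alkyl chain exchange in a TRPV1 antagonist series

This account rests on a few compounds, and the source may have more. Where it says the series, first, only, none or still open, it means among the compounds named here.

Measured so far:
compound 1 `CCCCCSc1nc(C(C)(C)C)ccc1CNC(=O)C(C)c1ccc(NS(C)(=O)=O)c(F)c1` — 3.1 nM
compound 2 `CC(C(=O)NCc1ccc(C(C)(C)C)nc1SC1CCCC1)c1ccc(NS(C)(=O)=O)c(F)c1` — 2.5 nM

Both compounds were run in an assay on cells for antagonist activity at transient receptor potential cation channel subfamily V member 1 (Homo sapiens), read by FLIPR and calcium flux, with a stated time of 6 min; on this read-out higher numbers stand for weaker inhibition and lower numbers for stronger inhibition. Compound 2 gives 2.5 nM, the lowest of the two numbers, with compound 1 nearest at 3.1 nM; the two values lie within the scatter of each other, so no order between them can be stated.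

Within the data shown here, the one measured step, a 1.2-fold lower number from compound 1 to compound 2 (0.09 log units; within the scatter), concerns the group on the sulfur and changes nothing beyond the scatter.

Compound 3 `CCCCCc1nc(C(C)(C)C)ccc1CNC(=O)C(C)c1ccc(NS(C)(=O)=O)c(F)c1` is not yet measured. It differs from compound 2 by pentyl in place of cyclopentylsulfanyl on an aromatic carbon. Among the measured compounds shown here, this change removes the sulfur, which no measured pair addresses; the step from compound 1 to compound 2 varies only the carbon group on that sulfur and is therefore of limited bearing. The expectation for this assay is a step of modest size, if any, in either direction.

Compound 3 is expected to give 5 nM, within 1.5 nM to 20 nM, which corresponds to an estimated step of a 2.0-fold higher number from compound 2 to compound 3 (0.30 log units; within the scatter).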

Compound 3, inhibition constant: 1.9 nM
Estimate against measurement, compound 3: 2.6-fold (0.42 log units) above; the range from low to high includes it.
By their numbers in this assay, from the lowest: compounds 3, 2 and 1 (each within the scatter of the next).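

The sulfur at this position, on an aromatic carbon next to the ring nitrogen, is not needed to keep the number in the low nanomolar range in this assay: with the pentyl chain kept, its removal gives a 1.6-fold lower number from compound 1 to compound 3 (0.21 log units; within the scatter) and the exchange of cyclopentylsulfanyl for pentyl gives a 1.3-fold lower number from compound 2 to compound 3 (0.12 log units; within the scatter) in the same series. The earlier step varied only the carbon group on the sulfur, whereas these two steps show that a pentyl chain attached directly to the aromatic carbon cannot be told apart from either sulfur-linked group on this read-out, with compound 3 at 1.9 nM as a value equivalent to the others within the scatter. No measurement in hand accounts for this tolerance of the exchange.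

Open, on these data alone, is how far this tolerance extends, since all three groups are carbon chains or rings of similar size, with or without the sulfur. A much shorter ethyl group, a longer chain such as octyl, an ether oxygen in place of the sulfur, or an amine at this position would show whether the flat picture holds beyond these three compounds.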